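Pyridyl-to-phenyl swap on the anilino nitrogen: cytotoxicity outlook

The compounds below may be only part of what the source reports. "The series", "measured", "known", "first", "only" and "open" are said of these compounds alone.

Measured so far:
compound 1 `COc1ccn2c(Nc3cc(Cl)ccc3Cl)c(-c3ccccn3)nc2c1` — 8930 nM
compound 2 `COc1ccn2c(Nc3ccc(F)cn3)c(-c3ccccn3)nc2c1` — 16000 nM

Two compounds of the shared core have been run in an ADME assay on THP-1 cells (Homo sapiens) for cytotoxicity; on this read-out higher numbers stand for lower toxicity in this test and lower numbers for higher toxicity in this test. Going by the values given here, compound 1 gives 8930 nM and compound 2 gives 16000 nM; the two values sit within the usual scatter of each other, as the single recorded step shows: a 1.8-fold higher number from compound 1 to compound 2 (0.25 log units; within the scatter). Compound 2 therefore stands nowhere apart from compound 1 on the numbers available.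

Compound 3 `COc1ccn2c(Nc3ccc(F)cc3)c(-c3ccccn3)nc2c1` is not yet measured. The change from compound 2 is 4-fluorophenyl in place of 5-fluoropyridin-2-yl on a nitrogen on an aromatic ring. Among the compounds with values here, the one step that bears on this position, from compound 1 to compound 2, exchanged the whole aryl group on that nitrogen and produced no movement beyond the scatter. A smaller exchange, pyridine to benzene with the fluorine retained, is expected to do no more; the estimated step is a 1.3-fold lower number from compound 2 to compound 3 (0.12 log units; within the scatter), with the number for compound 3 expected to lie between those of compound 1 and compound 2. Compound 3 is estimated at 12000 nM, range 5000 nM to 30000 nM.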

Compound 3, half-maximal cytotoxic concentration: 4560 nM
The estimate for compound 3 lay 2.6-fold (0.42 log units) above the measured number; measured number outside the range, below it.
By their numbers in this assay, from the lowest: compounds 3, 1 and 2 (each within the scatter of the next, the first and the last beyond it).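

In this assay, this position does respond to the aryl group. Going by these compounds alone, with the fluorine retained, 4-fluorophenyl in place of 5-fluoropyridin-2-yl, which removes the ring hetero atom and its hydrogen-bond acceptor, gives a 3.5-fold lower number from compound 2 to compound 3 (0.55 log units; beyond the scatter); this is the first step beyond the scatter, and it points to higher toxicity in this test for the carbon-only ring of compound 3. Within the data shown here, the two carbon-only aryl groups stay unresolved, with a 2.0-fold lower number from compound 1 to compound 3 (0.29 log units; within the scatter), so the only separation on the numbers is between the 5-fluoropyridin-2-yl of compound 2 and the 4-fluorophenyl of compound 3, and compound 1 falls within the scatter of both. Nothing measured here accounts for the gap between compound 2 and compound 3.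

The compounds shown leave open whether the gap holds for other pairs of this kind, since it rests on a single matched pair, and whether unsubstituted pyridin-2-yl and phenyl would separate in the same way. Also open, as far as these compounds go, is how a pyrimidin-2-yl ring, or an aryl group carrying an amine or a carboxylic acid, would read at this nitrogen.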